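Moving one hydroxy group: what compound 3 may show

A few compounds are considered here, and "the series" means these few. Any claim that something is new, unique, unknown or untested is made for them only; others in the source may bear on it.

Among the compounds with values here, in a functional assay on HeLa cells (Homo sapiens) for cytotoxicity, read by MTT assay (a higher number here means a weaker inhibitor, a lower number a stronger inhibitor), compound 2 `COc1cc(O)c(CC=C(C)C)c(O)c1C(=O)/C=C/c1ccc(O)c(O)c1` gives 2500 nM, the lowest of the two numbers so far, while compound 1 `COc1cc(O)c(CC=C(C)C)c(O)c1C(=O)/C=C/c1cc(O)c(O)c(O)c1` gives 30300 nM. Compound 3 `COc1cc(O)c(CC=C(C)C)c(O)c1C(=O)/C=C/c1cc(O)cc(O)c1` carries 3,5-dihydroxyphenyl in place of 3,4-dihydroxyphenyl on a double-bonded chain carbon bound to a double-bonded chain carbon. Within the data shown here, only one measured step bears on this, a large one with hydrogen in place of hydroxy on an aromatic carbon: a 12-fold lower number from compound 1 to compound 2 (1.08 log units; beyond the scatter). It involves no moved group, so only a moderate rise is expected in this assay, an estimated 2.8-fold higher number from compound 2 to compound 3 (0.45 log units; beyond the scatter). For compound 3 the estimated value is 7000 nM, within a range of 2000 nM to 30000 nM.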

Compound 3, half-maximal inhibitory concentration: 3200 nM
Beside the measured number, compound 3's estimate is 2.2-fold (0.34 log units) above it; the measured number falls inside the stated range.
By their numbers in this assay, from the lowest: compounds 2 and 3 (each within the scatter of the next); then compound 1.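

In this assay, moving one hydroxy group on the ring gives a 1.3-fold higher number from compound 2 to compound 3 (0.11 log units; within the scatter), so 3,4-dihydroxyphenyl and 3,5-dihydroxyphenyl cannot be told apart at this place. Removing a different hydroxy group from compound 1 also gives a step beyond the scatter, a 9.5-fold lower number from compound 1 to compound 3 (0.98 log units; beyond the scatter), so the earlier drop is not tied to one particular hydroxy group among these two. No measurement shown explains why the two arrangements match. Still open, on these data alone, is whether an amine or a carboxylic acid in place of a hydroxy group on this ring would give a similar number.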